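From a Direct Ring Link to an Amide Bridge

The source may report more compounds than this note shows. Statements on the series, on what has been measured and on what is new or still open speak of the compounds shown alone.

Compound 1 `Cc1cc(C)c(S(=O)(=O)N2CCC(N3CCC(C)CC3)CC2)c(C)c1` carries a sulfonyl group on a six-membered saturated ring that bears a second saturated ring directly. In an ADME assay on HCT-116 cells (Homo sapiens) for cytotoxicity, read by CellTiter-Glo, with a stated time of 72 h (on this read-out higher numbers stand for weaker inhibition and lower numbers for stronger inhibition), compound 1 gives > 5000 nM, which is a limit of the assay rather than a number. For the measured compounds named here, compound 2 `C#CCCC(=O)CC1CCN(C2CCN(S(=O)(=O)c3c(C)cc(C)cc3C)CC2)CC1` is the only other measured compound. In this assay compound 2 gives > 5000 nM, again a limit. The step that the two limits leave unreadable from compound 1 to compound 2 therefore cannot be read, and the limit of > 5000 nM in this assay, at which 2 of the 2 values shown sit, shows where both measured values sit.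

Compound 3 `Cc1cc(C)c(S(=O)(=O)N2CCC(C(=O)N3CCC(C)CC3)CC2)c(C)c1` differs from compound 1 in one place: (4-methylpiperidin-1-yl)carbonyl in place of 4-methylpiperidin-1-yl on a saturated ring carbon. Going by the values given here, no measured step involves a carbonyl set between the two rings; the single measured step, which is unreadable, offers no direction, and the expectation is that the change alters little in a compound whose value already sits at a limit. Compound 3 is expected to give 10000 nM, between 5000 nM and 40000 nM, an estimated step that the limit leaves unreadable from compound 1 to compound 3, most likely once more reported only as a limit.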

Compound 3, half-maximal inhibitory concentration: > 5000 nM
Compound 3 ended at the assay's limit; the forecaster's own chance of this, stated with the estimate: 85%; the middle value does not contradict the limit.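

In this assay compound 3 gives > 5000 nM which is a limit and not a number. Compound 1 also stands at a limit, so the step from compound 1 to compound 3 cannot be read. Still open is how strongly any of these compounds acts on the cells, or whether the (4-methylpiperidin-1-yl)carbonyl group changes anything: the limit of > 5000 nM in this assay, at which 3 of the 3 values shown sit.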